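Aryl Swap on the Ring Carbon: Compound 3 Expected

The source may hold more compounds than are shown below. What is called first, only, known or untested is meant among the compounds shown, and "the series" means these compounds.

compound 1 `CC1=C(C(=O)Nc2ccc(Br)cc2)C(c2ccc(Cl)cc2Cl)N=C(SCc2cccc(Cl)c2)N1` 15.4%
compound 2 `CC1=C(C(=O)Nc2ccc(Br)cc2)C(c2ccc(Cl)cc2Cl)N=C(SCc2ccc(F)cc2)N1` 33.3%

In a functional assay on the whole organism (artery, strain albino) with Rattus norvegicus as the target, with a stated time of 600 min, at a dose of 10 mg/kg by the oral route (a higher number here means more inhibition at the dose given (going by the name of the read-out), a lower number less inhibition), compound 1 gives 15.4% and compound 2 gives 33.3%, so compound 2 stands highest of the two, with a number 17.9 percentage points higher from compound 1 to compound 2 (beyond the scatter). Compound 3 `COc1ccc(C2N=C(SCc3ccc(F)cc3)NC(C)=C2C(=O)Nc2ccc(Br)cc2)cc1` differs from compound 2 by 4-methoxyphenyl in place of 2,4-dichlorophenyl on a saturated ring carbon. Among the compounds with values here, no measured step touches that ring carbon; the only step seen changes the group on the sulfur, so it gives no guide here. Compound 3 is therefore expected to stay near compound 2, with a number 3.3 percentage points lower from compound 2 to compound 3 (within the scatter) not beyond the scatter. The estimate for compound 3 is 30%, between 10% and 50%.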

Compound 3, a percentage reported as inhibition, in the whole organism at one dose (the size of the read-out at that dose, not a potency): 24.1%
The estimate for compound 3 lay 5.9 percentage points above the measured number; measured number inside the range.
By their numbers in this assay, from the lowest: compounds 1, 3 and 2 (each within the scatter of the next, the first and the last beyond it).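

Within the data shown here, at the saturated ring carbon, 4-methoxyphenyl in place of 2,4-dichlorophenyl gives, in this assay, a number 9.2 percentage points lower from compound 2 to compound 3 (within the scatter), the first reading at this position. This swap of two aryl groups of equal heavy-atom count, one adding a hydrogen-bond acceptor, therefore produces no step beyond the scatter. Nothing available explains this result.

Open, from the compounds shown here alone, is whether an amine or a carboxylic acid on this aryl ring would stay within the scatter of compound 2. Also open, going by these compounds, is whether the same swap would read alike with the 3-chlorophenyl group of compound 1.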